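Chain unsaturation in the enol acyl series

This account rests on a few compounds, and the source may have more. Where it says the series, first, only, none or still open, it means among the compounds named here.

Compound 2 `CCCCCCCCCCCCCCCCC/C(O)=C1/C(=O)[C@H](Cc2ccccc2)N(C(=O)OC(C)(C)C)C1=O` is the weaker of the two measured compounds in an assay on isolated protein for inhibition of kallikrein-5 (Homo sapiens); a higher number here means a weaker inhibitor, a lower number a stronger inhibitor: compound 2 gives 17000 nM, while compound 1 `CCCCCCCCCCCCC/C(O)=C1/C(=O)[C@H](Cc2ccccc2)N(C(=O)OC(C)(C)C)C1=O` gives 4900 nM. For the measured compounds named here, the only measured step, a 3.5-fold higher number from compound 1 to compound 2 (0.54 log units; beyond the scatter), lengthens the saturated chain and is modest in size. Compound 3 `CCCCCCCC/C=C\CCCCCCC/C(O)=C1/C(=O)[C@H](Cc2ccccc2)N(C(=O)OC(C)(C)C)C1=O` keeps the chain length of compound 2 and introduces one double bond: dec-1-en-1-yl in place of decyl on a saturated chain carbon, seven bonds along the chain from a double-bonded chain carbon. Going by the values given here, no measured step bears directly on unsaturation within the chain; the single step available concerns chain length alone and therefore offers no guidance on direction. With the chain length unchanged, no step beyond the scatter is expected for compound 3, a 1.3-fold lower number from compound 2 to compound 3 (0.12 log units; within the scatter). The estimate for compound 3 in this assay is 13000 nM, with a range of 4500 nM to 40000 nM, reflecting the absence of any measured unsaturation step.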

Compound 3, half-maximal inhibitory concentration: 1800 nM
Compound 3: the middle estimate sits 7.2-fold (0.86 log units) above what was measured; measured number outside the range, below it.
By their numbers in this assay, from the lowest: compound 3; then compound 1; then compound 2.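

In this assay, one double bond with the chain length held gives a 9.4-fold lower number from compound 2 to compound 3 (0.98 log units; beyond the scatter) and so runs opposite to the lengthening step between the saturated chains. Compound 3 also differs from the shorter saturated compound 1 by a 2.7-fold lower number from compound 1 to compound 3 (0.43 log units; beyond the scatter) and thus, among these three compounds, chain length alone does not set the order. Nothing measured here explains the effect of the double bond.

The compounds shown do not tell whether the lower number depends on the cis geometry of compound 3 or would hold for the trans double bond, a triple bond or a second double bond. They also leave open how a chain ending in a carboxylic acid or an amine would compare with dec-1-en-1-yl.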